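Acetyl for methyl on the ether chain of compound 1

The source may report more compounds than this note shows. Statements on the series, on what has been measured and on what is new or still open speak of the compounds shown alone.

Compound 1 `CCOc1nc(N)nc2[nH]cnc12` sits at a limit of an assay on HT-29 cells for inhibition of Methylated-DNA--protein-cysteine methyltransferase (Homo sapiens) (a higher number here means a weaker inhibitor, a lower number a stronger inhibitor), > 1000000 nM.
Compound 2 `CCCCCCOc1[nH]c(N)nc2ncnc1-2` gives 554000 nM in this assay.
Compound 3 `C=C(C)[C@H]1CC=C(COc2nc(N)nc3[nH]cnc23)CC1` gives 2600 nM in this assay.

Compound 1 stands at the weak end: its value is only a limit, not a number (the limit of > 1000000 nM in this assay, at which 1 of the 3 values shown sits). Compound 2 carries a longer chain on the same oxygen and reaches a number; compound 3, with its ring-bearing chain, reaches a far lower one. Compound 4 `CC(=O)COc1nc(N)nc2[nH]cnc12` differs from compound 1 by acetyl in place of methyl on a saturated chain carbon bound to an oxygen on an aromatic ring. Going by the values given here, no measured pair shows this change. The step from compound 1 to compound 4 is expected to be small and of uncertain direction, perhaps no more than the scatter, as an at least 1.6-fold lower number from compound 1 to compound 4 (0.22 log units; that floor lies within the scatter). Compound 4 is therefore estimated at 600000 nM, between 60000 nM and 3000000 nM.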

Compound 4, half-maximal inhibitory concentration: 192000 nM
Estimate against measurement, compound 4: 3.1-fold (0.49 log units) above; the range from low to high includes it.
By their numbers in this assay, from the lowest: compound 3; then compound 4; then compound 2. At a limit, above all of these: compound 1.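

Acetyl in place of methyl on a saturated chain carbon bound to an oxygen on an aromatic ring gives an at least 5.2-fold lower number from compound 1 to compound 4 (0.71 log units; beyond the scatter) in this assay. This change alone brings a measured number at this position, with no ring added to the chain. The size of the step is only a floor because the value of compound 1 is a limit: the limit of > 1000000 nM in this assay, at which 1 of the 4 values shown sits.

The compounds shown do not separate the carbonyl from the added chain carbons. A propyl chain or a 2-hydroxypropyl chain on the same oxygen would bear on that question.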